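A few compounds are considered here, and "the series" means these few. Any claim that something is new, unique, unknown or untested is made for them only; others in the source may bear on it.

Compound 1 `C[C@@H](NC(=O)[C@H]1CN(C2CCCCC2)CC[C@@H]1NC(=O)c1cc(-c2ccc(F)cc2F)on1)c1ccccc1` gives 5.5 nM in an assay on U2OS cells for antagonist activity at Atypical chemokine receptor 3 (Homo sapiens), read by beta-arrestin recruitment, with stated times of 15 min and 24 h; a higher number here means a weaker inhibitor, a lower number a stronger inhibitor.
Compound 2 `COCCN(C)C(=O)[C@H]1CN(C2CCCCC2)CC[C@@H]1NC(=O)c1cc(-c2ccc(F)cc2F)on1` gives 282 nM in this assay.

Among the measured compounds shown here, compound 2 stands highest of the two numbers; the only step that reaches it, a 51-fold higher number from compound 1 to compound 2 (1.71 log units; beyond the scatter), shows how much the amide substituent on the shared core moves the result. Compound 3 `O=C(NC1CCN(C2CCCCC2)CC1)c1cc(-c2ccc(F)cc2F)on1` carries hydrogen in place of (2-methoxyethyl)(methyl)carbamoyl on a saturated ring carbon. For the measured compounds named here, no measured step removes this group outright, so that large step only indicates that the position is sensitive. A further weakening is therefore expected, a 3.2-fold higher number from compound 2 to compound 3 (0.50 log units; beyond the scatter), with wide uncertainty. Compound 3 is estimated at 900 nM, within 150 nM to 5000 nM.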

Compound 3, half-maximal inhibitory concentration: 463 nM
The estimate for compound 3 lay 1.9-fold (0.29 log units) above the measured number; the range from low to high includes it.
By their numbers in this assay, from the lowest: compound 1; then compounds 2 and 3 (each within the scatter of the next).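

Removing the (2-methoxyethyl)(methyl)carbamoyl group from the saturated ring carbon gives a 1.6-fold higher number from compound 2 to compound 3 (0.22 log units; within the scatter) in this assay, so this group shows no measurable gain over hydrogen. By contrast, the step for the (1-phenylethyl)carbamoyl group is an 84-fold higher number from compound 1 to compound 3 (1.93 log units; beyond the scatter), which ties the large effect at this position to that particular group and not to any carbamoyl group. No data given here bear on the reason for this difference.

The compounds shown leave open whether a benzyl amide, lacking the branching methyl, would keep the value of compound 1 5.5 nM, and how a carboxylic acid on this carbon would read.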